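The compounds below may be only part of what the source reports. "The series", "measured", "known", "first", "only" and "open" are said of these compounds alone.

Measured so far in a functional assay on KB cells (Homo sapiens) for antiproliferative activity, read by MTT assay, with a stated time of 72 h; on this read-out lower numbers stand for stronger inhibition and higher numbers for weaker inhibition:
compound 1 `CN(C(=O)C(C)(C)C)c1ccc2[nH]c(-c3n[nH]c4ccccc34)cc2n1` — 8390 nM
compound 2 `Cc1ccc(S(=O)(=O)N(C)c2ccc3[nH]c(-c4n[nH]c5ccccc45)cc3n2)cc1` — 9500 nM

Compound 1 is the starting point of the step considered here. Against compound 2, the only other measured compound, the step is a 1.1-fold higher number from compound 1 to compound 2 (0.05 log units; within the scatter), so the two numbers cannot be told apart and compound 1 cannot be placed ahead of or behind it.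

Compound 3 `CN(c1ccc2[nH]c(-c3n[nH]c4ccccc34)cc2n1)S(=O)(=O)c1ccc(Br)cc1` differs from compound 1 as follows: (4-bromophenyl)sulfonyl in place of (tert-butyl)carbonyl on a nitrogen on an aromatic ring

For the measured compounds named here, the one measured step that bears on this change is the one from compound 1 to compound 2, where a (4-methylphenyl)sulfonyl also replaced the (tert-butyl)carbonyl on the same nitrogen; that step was a 1.1-fold higher number from compound 1 to compound 2 (0.05 log units; within the scatter). The change to compound 3 is of the same kind, so no step beyond the scatter is expected in this assay, in either direction. The estimated step is a 1.1-fold higher number from compound 1 to compound 3 (0.05 log units; within the scatter). Compound 3 is therefore expected to give about 9500 nM, in the range 4500 nM to 20000 nM.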

Compound 3, half-maximal inhibitory concentration: 7150 nM
For compound 3 the middle estimate is 1.3-fold (0.12 log units) above the measured one; the range from low to high includes it.
By their numbers in this assay, from the lowest: compounds 3, 1 and 2 (each within the scatter of the next).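

In this assay, a second arylsulfonyl group on this nitrogen, (4-bromophenyl)sulfonyl, again stays within the scatter of the (tert-butyl)carbonyl compound (a 1.2-fold lower number from compound 1 to compound 3 (0.07 log units; within the scatter)), so the result with (4-methylphenyl)sulfonyl is no longer a single case. The substituent on the phenyl ring of the sulfonyl group has now also been varied: bromo in place of methyl (a 1.3-fold lower number from compound 2 to compound 3 (0.12 log units; within the scatter)) likewise cannot be told apart from the scatter. Across these three compounds, neither the swap of carbonyl for sulfonyl nor this change on the phenyl ring separates the numbers.

No step shown lies beyond the scatter, so it remains open whether anything at this nitrogen can move the number. An amine or a carboxylic acid on the phenyl ring, or a plain hydrogen in place of the acyl or sulfonyl group, would test this. Nothing available bears on what lies behind these numbers.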